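Series notes: the fluorobenzyl swap on a second core

The source may hold more compounds than are shown below. What is called first, only, known or untested is meant among the compounds shown, and "the series" means these compounds.

Measured so far:
compound 1 `O=C(/C=C/c1ccc(OCc2cn(Cc3ccccc3F)nn2)cc1)c1ccc(Br)cc1`: 28%
compound 2 `O=C(/C=C/c1ccc(OCc2cn(Cc3cccc(F)c3)nn2)cc1)c1ccc(Br)cc1`: 34%
compound 3 `O=C(/C=C/c1ccc(OCc2cn(Cc3ccccc3F)nn2)cc1)c1ccc([N+](=O)[O-])cc1`: 22%

In a functional assay on MIA PaCa-2 cells (Homo sapiens) for inhibition, read by MTT assay, with a stated time of 48 h, tested at 10 uM (a lower number here means less inhibition of growth, a higher number more inhibition of growth at the concentration tested), compound 1 gives 28%, compound 2 gives 34% and compound 3 gives 22%. Compound 2 differs from compound 1 by 3-fluorophenyl in place of 2-fluorophenyl on a saturated chain carbon bound to an aromatic nitrogen; the step is a number 6 percentage points higher from compound 1 to compound 2 (within the scatter). Compound 3 differs from compound 1 by nitro in place of bromo on an aromatic carbon; the step is a number 6 percentage points lower from compound 1 to compound 3 (within the scatter).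

Compound 4 `O=C(/C=C/c1ccc(OCc2cn(Cc3cccc(F)c3)nn2)cc1)c1ccc([N+](=O)[O-])cc1` has not been measured. It differs from compound 3 by 3-fluorophenyl in place of 2-fluorophenyl on a saturated chain carbon bound to an aromatic nitrogen, the same change as from compound 1 to compound 2, here made on the core of compound 3. The expected step in this assay is a number 6 percentage points higher from compound 3 to compound 4 (within the scatter), set beside a number 6 percentage points higher from compound 1 to compound 2 (within the scatter), on which it rests; one earlier instance is a thin basis, so the range is kept wide. Compound 4 is estimated at 28%, expected between 16% and 40%.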

Compound 4, percent growth inhibition at one concentration: 32%
For compound 4 the middle estimate is 4 percentage points below the measured one, within the range that was stated.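

In this assay, the change from 2-fluorobenzyl to 3-fluorobenzyl reads alike on the two cores: the same change on two cores in this assay, a number 6 percentage points higher (within the scatter) from compound 1 to compound 2 and a number 10 percentage points higher (within the scatter) from compound 3 to compound 4, 4 percentage points apart, within the scatter of two such steps. Nitro in place of bromo also reads alike on the two cores: the same change on two cores in this assay, a number 6 percentage points lower (within the scatter) from compound 1 to compound 3 and a number 2 percentage points lower (within the scatter) from compound 2 to compound 4, 4 percentage points apart, within the scatter of two such steps. With a number 10 percentage points higher from compound 3 to compound 4 (within the scatter) and a number 2 percentage points lower from compound 2 to compound 4 (within the scatter), the four compounds show no large dependence of either change on the core, but they do not show that either change has a real effect, or that the agreement would hold on another core.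

The compounds shown leave open how an amine or a carboxylic acid would read in place of bromo or nitro. They also leave open how a longer chain would read in place of the fluorobenzyl group.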